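The source may hold more compounds than are shown below. What is called first, only, known or untested is meant among the compounds shown, and "the series" means these compounds.

In a functional assay on MCF7 cells (Homo sapiens) for antiproliferative activity, with a stated time of 48 h (a lower number here means a stronger inhibitor, a higher number a weaker inhibitor), compound 1 `O=C(CCl)Nc1ccc(I)cc1` gives 6200 nM. Compound 2 `CC(C)(C)c1ccc(NC(=O)CCl)cc1` gives 5400 nM in this assay, and the change from compound 1 to compound 2, tert-butyl in place of iodo on an aromatic carbon, amounts to a 1.1-fold lower number from compound 1 to compound 2 (0.06 log units; within the scatter). Compound 2 thus stands beside compound 1 with the two numbers not separated beyond the scatter. Compound 3 `CC(C)(C)c1ccc(NC(=O)CCCCl)cc1` differs from compound 2 by 2-chloroethyl in place of chloro on a saturated chain carbon bound to a carbonyl carbon. For the measured compounds named here, the only measured step concerns the aromatic substituent, not the chain bound to the carbonyl, so no measured step bears on this change and the expectation rests on compound 2 alone. The number for compound 3 in this assay is therefore estimated with a wide range, at 12000 nM between 4000 nM and 40000 nM. This estimate means a step of a 2.2-fold higher number from compound 2 to compound 3 (0.35 log units; beyond the scatter) from compound 2 to compound 3, which is expected but not supported by any measured step.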

Compound 3, half-maximal inhibitory concentration: > 100000 nM
Compound 3: a limit, no number (the forecaster's own chance of this, stated with the estimate: 20%); at least 8.3-fold (0.92 log units) between middle value and limit.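

Compound 3 carries a limit of the assay and not a number: the limit of > 100000 nM in this assay, at which 1 of the 3 values shown sits.

In this assay, 2-chloroethyl in place of chloro on a saturated chain carbon bound to a carbonyl carbon brings an at least 18-fold higher number from compound 2 to compound 3 (1.26 log units; beyond the scatter), whereas the earlier step on the aromatic carbon, a 1.1-fold lower number from compound 1 to compound 2 (0.06 log units; within the scatter), did not leave the scatter. Among the compounds shown, the chain bound to the carbonyl is therefore the place where a change moves the number far, although this rests on a single step.

The compounds shown leave open whether a shorter chloroethyl chain, or a plain propyl chain without chlorine, would give a number close to that of compound 2 or to that of compound 3. They also leave open whether an amine or a hydroxyl in place of chloro on that carbon would keep the number near that of compound 2.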